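Moving a Ring Double Bond in Compound 1

The compounds below may be only part of what the source reports. "The series", "measured", "known", "first", "only" and "open" are said of these compounds alone.

In an ADME assay on L1210 cells (Mus musculus) for cytotoxicity, with a stated time of 48 h (on this read-out higher numbers stand for weaker inhibition and lower numbers for stronger inhibition), compound 1 (`C=C1[C@H](C)CCC[C@]1(C)CC/C(C)=C/CC1=C(O)C(=O)C=C(N[C@@H](C(=O)O)C(C)C)C1=O`) gives 3.4 ug/mL. Compound 3 (`C=C1[C@H](C)CCC[C@]1(C)CC/C(C)=C/CC1=C(O)C(=O)C=C(N[C@H](CO)C(=O)O)C1=O`) gives 2.6 ug/mL, and the two sit level, with a 1.3-fold lower number from compound 1 to compound 3 (0.12 log units; within the scatter). Compound 2 (`C=C1[C@H](C)CCC[C@]1(C)CC/C(C)=C/CC1=C(O)C(=O)C=C(N[C@H](C(=O)O)[C@@H](C)O)C1=O`) reads > 10 ug/mL, which is a limit of the assay. Measured against that limit, the other two steps are an at least 2.9-fold higher number from compound 1 to compound 2 (0.46 log units; beyond the scatter) and an at least 3.8-fold lower number from compound 2 to compound 3 (0.58 log units; beyond the scatter).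

Compound 4 (`CC1=CCC[C@](C)(CC/C(C)=C/CC2=C(O)C(=O)C=C(N[C@@H](C(=O)O)C(C)C)C2=O)[C@@H]1C`) has the same atoms as compound 1, joined differently: a group of 9 heavy atoms (9 carbon; one six-membered non-aromatic ring of carbon only) in place of a group of 9 heavy atoms (9 carbon; one six-membered non-aromatic ring of carbon only), on a saturated chain carbon, two bonds along the chain from a double-bonded chain carbon. The group that enters is 1,2,3-trimethylcyclohex-3-en-1-yl. None of the three measured steps touches this group, since each changes only the group on an amine nitrogen. They therefore bear on the new change only indirectly, and they give no sign of its size or direction. The anchor is the value of compound 1, 3.4 ug/mL, and no shift beyond the scatter is expected. The estimated step is a 1.0-fold higher number from compound 1 to compound 4 (0.01 log units; within the scatter). For compound 4 the estimated value is 3.5 ug/mL, with an expected range of 1.5 ug/mL to 8.5 ug/mL.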

Compound 4, half-maximal inhibitory concentration: 3 ug/mL
Estimate against measurement, compound 4: 1.2-fold (0.07 log units) above, within the range that was stated.
By their numbers in this assay, from the lowest: compounds 3, 4 and 1 (each within the scatter of the next). At a limit, above all of these: compound 2.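

In this assay, among the compounds shown here, the earlier steps changed only the group on an amine nitrogen, whereas here the change lies at the other end of the molecule: 1,2,3-trimethylcyclohex-3-en-1-yl enters on a saturated chain carbon, two bonds along the chain from a double-bonded chain carbon, giving a 1.1-fold lower number from compound 1 to compound 4 (0.05 log units; within the scatter). With the 1-carboxy-2-methylpropyl group held on the amine nitrogen, the same atoms joined differently at this place therefore leave the read-out within the scatter, in this one pair. Nothing shown gives a reason for this result.

The compounds shown leave open whether the same exchange would also leave the read-out within the scatter with the 1-carboxy-2-hydroxyethyl group on the amine nitrogen. They also leave open what a cyclohexyl ring without a double bond, or an open decyl chain, would give at this place.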